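The source may report more compounds than this note shows. Statements on the series, on what has been measured and on what is new or still open speak of the compounds shown alone.

Measured compounds, with the number from a functional assay on SJSA-1 cells (Homo sapiens) for inhibition, read by CCK-8 assay, with a stated time of 72 h, tested at 1 uM (a lower number here means less inhibition, a higher number more inhibition at the concentration tested (going by the name of the read-out)), for each:

compound 1 `COc1ccc(OC)c(N2C(=O)CSC2c2cccc(C(=O)NCCCCc3ccccc3)c2)c1` — 48%
compound 2 `COc1ccccc1N1C(=O)CSC1C(=O)NCCCCc1ccccc1` — 14%
compound 3 `Cc1cccc(N2C(=O)CSC2c2cccc(C(=O)NCCCCc3ccccc3)c2)c1` — 84%

Compound 3 gives the highest number of the three in this assay; its nearest neighbour is compound 1, and the gap from compound 1 to compound 3 is a number 36 percentage points higher from compound 1 to compound 3 (beyond the scatter), so the substitution on the aryl ring attached to the amide-type nitrogen in the ring moves the number strongly. Compound 2, which lacks the phenyl spacer and carries a different aryl group, shows the lowest number of the three.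

Compound 4 `O=C(NCCCCc1ccccc1)c1cccc(C2SCC(=O)N2c2cccc(F)c2)c1` is the next compound for this assay. It differs from compound 3 by fluoro in place of methyl on an aromatic carbon. Going by the values given here, no measured pair shows a methyl exchanged for a fluoro on this ring; the only bearing step is the one from compound 1 to compound 3, which says that changes on this ring can be large but gives no direction for this particular swap. A small retention of activity with some loss is expected, the estimated step being a number 19 percentage points lower from compound 3 to compound 4 (beyond the scatter). For compound 4 the expected value in this assay is 65%, with an estimated range from 35% to 90%.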

Compound 4, a percentage reported as inhibition, at one concentration (the size of the read-out at that concentration, not a potency): 80%
Beside the measured number, compound 4's estimate is 15 percentage points below it; the range from low to high includes it.
By their numbers in this assay, from the lowest: compound 2; then compound 1; then compounds 4 and 3 (each within the scatter of the next).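

In this assay, the exchange of 3-methylphenyl for 3-fluorophenyl gives a number 4 percentage points lower from compound 3 to compound 4 (within the scatter), so this position does not separate methyl from fluoro. Compared with 2,5-dimethoxyphenyl, 3-fluorophenyl gives a number 32 percentage points higher from compound 1 to compound 4 (beyond the scatter), close to the earlier a number 36 percentage points higher from compound 1 to compound 3 (beyond the scatter), so among these three compounds the higher number does not depend on methyl alone. Nothing measured here accounts for this.

Still open, going by these compounds, is whether the number holds with an unsubstituted phenyl, or with an amine, a carboxylic acid or a trifluoromethyl at the same place on the ring. Also open, on these data alone, are which of the two methoxy groups goes with the lower number of compound 1, and what a longer chain on the amide would do.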